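This account rests on a few compounds, and the source may have more. Where it says the series, first, only, none or still open, it means among the compounds named here.

Of the compounds shown here, three that share one core have been tested in an assay on cells for inhibition of thyroid peroxidase (Homo sapiens), with stated times of 10 min and 15 min; on this read-out higher numbers stand for weaker inhibition and lower numbers for stronger inhibition. Compound 1 `Nc1cc(Cc2ccn(-c3cccc(-c4ccccc4)c3)n2)c2nn[nH]c2n1` gives 710 nM in this assay. Compound 2 `Nc1cc(Cc2ccn(Cc3ccc4ccccc4c3)n2)c2nn[nH]c2n1` gives 1100 nM. Compound 3 `Nc1cc(Cc2ccn(Cc3cccc(Oc4cccc5c4CNC5)c3)n2)c2nn[nH]c2n1` gives 1700 nM, the highest of the three numbers; its gap to compound 2 lies within the usual scatter of repeated measurements, while its gap to compound 1 is beyond that scatter, so compound 1 stands as the stronger inhibitor of the two.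

Compound 4 `Nc1cc(Cc2ccn(Cc3ccccc3)n2)c2nn[nH]c2n1` differs from compound 3 in one place: a hydrogen atom in place of a group of 10 heavy atoms (8 carbon, 1 nitrogen, 1 oxygen; one five-membered non-aromatic ring with 1 hetero atom, one six-membered aromatic ring of carbon only), on an aromatic carbon. The whole group is removed from the six-membered aromatic ring of carbon only, leaving a plain hydrogen on that aromatic carbon. For the measured compounds named here, no measured pair shows this exact change, so the expected size of the step in this assay rests only on the spread among compounds 1, 2 and 3. Compound 2, which also lacks this large group, gives 1100 nM, close to the number of compound 3. A step of modest size, in either direction or none beyond the scatter, is the expectation. Compound 4 is expected to give about 1500 nM, within a range from 500 nM to 4500 nM. That expectation amounts to a step of a 1.1-fold lower number from compound 3 to compound 4 (0.05 log units; within the scatter) in this assay.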

Compound 4, half-maximal inhibitory concentration: 2300 nM
For compound 4 the middle estimate is 1.5-fold (0.19 log units) below the measured one; the measured number falls inside the stated range.
By their numbers in this assay, from the lowest: compounds 1, 2, 3 and 4 (each within the scatter of the next, the first and the last beyond it).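

Taking away the whole group of 10 heavy atoms, with its five-membered non-aromatic ring and its six-membered aromatic ring of carbon only, and leaving a plain hydrogen on that aromatic carbon, amounts in this assay to a 1.4-fold higher number from compound 3 to compound 4 (0.13 log units; within the scatter). For the compounds shown here, this pair gives the first direct reading at this position, and the read-out does not separate the large group from a hydrogen atom, so this one change shows neither a gain nor a loss in inhibition beyond ordinary measurement noise. No measurement offered here explains this outcome.

Going by these compounds, the change removes the group as a whole, so the separate contributions of its two rings remain unknown, and a phenoxy group on the same aromatic carbon, lacking the five-membered ring, would be one way to begin pulling them apart. On these data alone, whether a much smaller group at this place, such as a fluorine atom, a methoxy group or a carboxylic acid, would move the number beyond the scatter also remains open.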